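A few compounds are considered here, and "the series" means these few. Any claim that something is new, unique, unknown or untested is made for them only; others in the source may bear on it.

Measured so far:
- compound 1, `O=C(CSc1nc2c(c(=O)n1-c1ccccc1)SCC2)Nc1ccc(-c2ccccn2)cc1`: 4 nM
- compound 2, `O=C(CSc1nc2c(c(=O)n1-c1ccccc1)SCC2)Nc1ccc(-c2ccoc2)cn1`: 1.5 nM

Both compounds share one core and one amide linker; they differ only in the aryl group carried by the anilide. In an assay on L cells for inhibition of Protein-serine O-palmitoleoyltransferase porcupine (Mus musculus), read by reporter gene assay, with a stated time of 24 h (on this read-out lower numbers stand for an effect already at smaller amounts and higher numbers for an effect only at larger amounts of compound), compound 1 gives 4 nM, the higher of the two numbers, and compound 2 gives 1.5 nM, a gap that lies beyond the usual scatter. Within the data shown here, no single-point step between measured compounds exists, so the step from compound 1 to compound 3 has no measured counterpart.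

Compound 3, `CN(C)c1ccc(NC(=O)CSc2nc3c(c(=O)n2-c2ccccc2)SCC3)cc1`, is not yet measured. It differs from compound 1 by dimethylamino in place of pyridin-2-yl on an aromatic carbon. Because compound 1 already gives 4 nM and both measured anilides carry a second aromatic ring at that carbon, the loss of the ring is expected to cost some potency in this assay, with a step of a 6.3-fold higher number from compound 1 to compound 3 (0.80 log units; beyond the scatter) expected. The estimate for compound 3 in this assay is 25 nM, with an expected range from 5 nM to 150 nM.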

Compound 3, half-maximal effective concentration: > 1000 nM
Compound 3: no number, only a limit; the forecaster's own chance of this, stated with the estimate: 5%; middle value at least 40-fold (1.60 log units) from the limit.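

Swapping pyridin-2-yl for dimethylamino on this aromatic carbon, para to a large group, gives an at least 250-fold higher number from compound 1 to compound 3 (2.39 log units; beyond the scatter) in this assay, which shows that activity depends strongly on the group at this position. The reading for compound 3, > 1000 nM, is a limit and not a number, so the step gives only a minimum size: the limit of > 1000 nM in this assay, at which 1 of the 3 values shown sits. The hydrogen-bond donor and acceptor counts and the net charge are the same for both groups, so the counted difference lies in the ring and the heavy-atom count.

The compounds shown do not separate the loss of the aromatic ring from the loss of size. A morpholin-4-yl group, a saturated ring, or a longer chain such as an n-butyl group at this carbon would bear on that question.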